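The source may hold more compounds than are shown below. What is called first, only, known or untested is meant among the compounds shown, and "the series" means these compounds.

Working notes on the series.

Compound 1, `COc1ccc(N/C(CCNC2=CC(=O)c3ccccc3C2=O)=N\S(=O)(=O)c2ccc(C)cc2)cc1OC`, is one of two compounds with a number in an ADME assay on HEK293 cells (Homo sapiens) for cytotoxicity, read by MTT assay, with a stated time of 48 h; on this read-out higher numbers stand for weaker inhibition and lower numbers for stronger inhibition; in this assay compound 1 gives 60600 nM, the lower of the two numbers. Among the compounds with values here, compound 2, `Cc1ccc(S(=O)(=O)/N=C(/CCNC2=CC(=O)c3ccccc3C2=O)NC(C)C)cc1`, is its only neighbour; in this assay compound 2 gives 71600 nM. Within the data shown here, the single step with a measurement runs from compound 1 to compound 2, a 1.2-fold higher number from compound 1 to compound 2 (0.07 log units; within the scatter), and it concerns the substituent on the amine nitrogen, not the sulfonyl aryl ring.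

Compound 3, `COc1ccc(N/C(CCNC2=CC(=O)c3ccccc3C2=O)=N\S(=O)(=O)c2ccc(C(C)(C)C)cc2)cc1OC`, is not yet measured. Against compound 1 it differs in one place: tert-butyl in place of methyl on an aromatic carbon. Among the measured compounds shown here, no measured step touches this position, so the only guide is that the one change made so far, from compound 1 to compound 2, stayed within the scatter. On that basis the step from compound 1 to compound 3 is expected to be small as well, a 1.0-fold lower number from compound 1 to compound 3 (0.00 log units; within the scatter), with no direction that can be defended from the numbers in hand. The value expected for compound 3 in this assay is 60000 nM, in the range 30000 nM to 120000 nM, pending the measurement.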

Compound 3, half-maximal inhibitory concentration: 62300 nM
Estimate against measurement, compound 3: 1.0-fold (0.02 log units) below; the measured number falls inside the stated range.
By their numbers in this assay, from the lowest: compounds 1, 3 and 2 (each within the scatter of the next).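

In this assay, within the data shown here, the step at this position is a 1.0-fold higher number from compound 1 to compound 3 (0.01 log units; within the scatter) and gives the first reading for a substituent on an aromatic carbon of a six-membered aromatic ring of carbon only, para to a large group. Going from 4-methylphenyl to 4-(tert-butyl)phenyl raises the count from 1 heavy atom to 4 heavy atoms in the group at this place, and the two numbers still cannot be told apart, so this size of alkyl group gives no readable step here. Nothing on hand accounts for this result, and the reading stays a description of the numbers only.

Whether a carboxylic acid, an amine or a methoxy group at this same place would also stay within the scatter of compound 1 remains open, since the two groups shown here are both plain alkyl groups. Also open, as far as these compounds go, is whether the result carries over to the core of compound 2, which has isopropyl on the amine nitrogen, or whether a longer chain on that nitrogen would alter the picture.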